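A few compounds are considered here, and "the series" means these few. Any claim that something is new, unique, unknown or untested is made for them only; others in the source may bear on it.

Measured so far in a functional assay on A2780 cells (Homo sapiens) for antiproliferative activity, read by sulforhodamine B assay, with a stated time of 72 h; a higher number here means a weaker inhibitor, a lower number a stronger inhibitor:
- compound 1 `C[C@@H]1CN(S(=O)(=O)c2ccc(NC(=O)NCc3cccnc3)cc2)C[C@H](C)O1`: 15 nM
- compound 2 `O=C(NCc1cccnc1)Nc1ccc(S(=O)(=O)N2C3CCC2COC3)cc1`: 251 nM
- compound 3 `CC1CNCCN(S(=O)(=O)c2ccc(NC(=O)NCc3cccnc3)cc2)C1`: 99 nM

Compound 3 holds the second highest of the three numbers, with compound 1 lower and compound 2 higher, and both gaps lie beyond the scatter. The next compound is compound 4 `N[C@H]1CC[C@H](NS(=O)(=O)c2ccc(NC(=O)NCc3cccnc3)cc2)CC1`. The change is a group of 8 heavy atoms (6 carbon, 2 nitrogen; one six-membered non-aromatic ring of carbon only) in place of a group of 8 heavy atoms (6 carbon, 2 nitrogen; one seven-membered non-aromatic ring with 2 hetero atoms), on a sulfonyl sulfur: (4-aminocyclohexyl)amino enters on a sulfonyl sulfur, and the two compounds have the same atoms, joined differently.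

All three measured steps are replacements at this same place: a 17-fold higher number from compound 1 to compound 2 (1.22 log units; beyond the scatter), a 6.6-fold higher number from compound 1 to compound 3 (0.82 log units; beyond the scatter) and a 2.5-fold lower number from compound 2 to compound 3 (0.40 log units; beyond the scatter). They range from modest to large, so a change here can clearly move the number. None of them, however, involves a six-membered non-aromatic ring of carbon only, so they give no direction for this change. No step beyond the scatter is therefore expected in this assay as the central call, although the uncertainty is wide. The expected step is a 1.5-fold higher number from compound 3 to compound 4 (0.18 log units; within the scatter). For compound 4 the estimated value is 150 nM, with an expected range of 30 nM to 700 nM.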

Compound 4, half-maximal inhibitory concentration: 52 nM
Beside the measured number, compound 4's estimate is 2.9-fold (0.46 log units) above it, and the stated range covers the measured number.
By their numbers in this assay, from the lowest: compound 1; then compounds 4 and 3 (each within the scatter of the next); then compound 2.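

In this assay, within the data shown here, (4-aminocyclohexyl)amino gives the first reading for a six-membered non-aromatic ring of carbon only on the sulfonyl sulfur, and a 1.9-fold lower number from compound 3 to compound 4 (0.28 log units; within the scatter) shows that this ring cannot be told apart from the seven-membered ring with 2 hetero atoms that it replaces. At this place, a 3.5-fold higher number from compound 1 to compound 4 (0.54 log units; beyond the scatter) leaves 2,6-dimethylmorpholin-4-yl as the strongest group so far, while a 4.8-fold lower number from compound 2 to compound 4 (0.68 log units; beyond the scatter) shows that the carbon-only ring clearly outperforms the two-ring group. Nothing available explains these differences.

From the compounds shown here alone, whether the amino group on the cyclohexyl ring contributes to the reading stays open, and a hydroxyl or a plain cyclohexylamino group at the same place would test this. Also open, going by these compounds, is whether another arrangement at the 2 defined stereocentres would read differently.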